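This account rests on a few compounds, and the source may have more. Where it says the series, first, only, none or still open, it means among the compounds named here.

Compound 1 `Cc1cc(C(=O)N2CCCCc3ccccc32)ccc1CNC(=O)Nc1ccccc1`, compound 2 `COC(=O)CNC(=O)NCc1ccc(C(=O)N2CCCCc3ccccc32)cc1C` and compound 3 `Cc1cc(C(=O)N2CCCCc3ccccc32)ccc1CNC(=O)NCC(=O)OC(C)C` share one core and differ only at the end of the urea. In a functional assay on HEK293 cells for agonist activity at Vasopressin V2 receptor (Homo sapiens), read by a luciferase reporter and cAMP accumulation (on this read-out lower numbers stand for an effect already at smaller amounts and higher numbers for an effect only at larger amounts of compound), compound 1 gives 130 nM, compound 2 gives 37 nM and compound 3 gives 140 nM, the highest of the three numbers; compound 1 sits within the scatter of it, while compound 2 lies clearly lower. Of the measured steps, a 3.5-fold lower number from compound 1 to compound 2 (0.55 log units; beyond the scatter) and a 3.8-fold higher number from compound 2 to compound 3 (0.58 log units; beyond the scatter) are modest, and a 1.1-fold higher number from compound 1 to compound 3 (0.03 log units; within the scatter) is within the scatter. Compound 4 `Cc1cc(C(=O)N2CCCCc3ccccc32)ccc1CNC(=O)NCC(=O)N(C)C` is not yet measured; it arises from compound 3 by dimethylamino in place of isopropoxy on a carbonyl carbon. The measured steps touch the same terminus: the size of the ester group moved the number modestly in this assay, and replacing phenyl by an ester changed it little or modestly. Going by the values given here, no measured pair shows an amide in this position, so the expectation rests on the whole terminus appearing tolerant. Compound 4 is therefore expected to show a 1.4-fold lower number from compound 3 to compound 4 (0.15 log units; within the scatter), a step not beyond the scatter, with an estimate of 100 nM and a range from 35 nM to 300 nM.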

Compound 4, half-maximal effective concentration: 58 nM
For compound 4 the middle estimate is 1.7-fold (0.24 log units) above the measured one; low and high end bracket the measured number.
By their numbers in this assay, from the lowest: compounds 2 and 4 (each within the scatter of the next); then compounds 1 and 3 (each within the scatter of the next).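

The amide is tolerated at this terminus in this assay: dimethylamino in place of isopropoxy on the carbonyl carbon gives a 2.4-fold lower number from compound 3 to compound 4 (0.38 log units; beyond the scatter), the first sign that this carbonyl need not carry an ester. The same exchange against the methoxy ester gives a 1.6-fold higher number from compound 2 to compound 4 (0.20 log units; within the scatter), so the amide matches the methyl ester here rather than the isopropyl ester. Set against the phenyl urea, (dimethylcarbamoyl)methyl in place of phenyl gives a 2.2-fold lower number from compound 1 to compound 4 (0.35 log units; beyond the scatter), and nothing available explains these steps.

Whether the step from compound 3 comes from the nitrogen or from the two methyl groups on it cannot be told from these compounds. From the compounds shown here alone, how a primary amide, a carboxylic acid or a longer chain at this terminus would read remains open.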